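An amino group on the fused ring of compound 1

The source may hold more compounds than are shown below. What is called first, only, known or untested is meant among the compounds shown, and "the series" means these compounds.

The series is judged in a functional assay on HeLa cells (Homo sapiens) for cytotoxicity, read by sulforhodamine B assay, with a stated time of 48 h; on this read-out lower numbers stand for stronger inhibition of growth and higher numbers for weaker inhibition of growth. Compound 1 `CCn1cc(-c2nc3ccccc3[nH]2)c(=O)c2cc(F)c(N3CCNCC3)cc21` reaches only the limit of the measurement, > 10000 nM, so no number stands for it. Two related compounds with a nitro group on a different fused ring and further substitution give numbers: compound 2 `CCn1cc(-c2nc3ccc([N+](=O)[O-])cc3o2)c(=O)c2cc(F)c(N3CCNC(C)C3)c(F)c21` gives 1100 nM in this assay, and compound 3 `CCn1cc(-c2nc3ccc([N+](=O)[O-])cc3s2)c(=O)c2cc(F)c(N3CCNC(C)C3)c(F)c21` gives 1700 nM. Going by the values given here, since compound 1 sits at the limit, (the limit of > 10000 nM in this assay, at which 1 of the 3 values shown sits), its distance from compounds 2 and 3 cannot be sized, and as no pair of measured compounds differs in one place, no single step is on record.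

Compound 4 `CCn1cc(-c2nc3ccc(N)cc3[nH]2)c(=O)c2cc(F)c(N3CCNCC3)cc21` is the one to be measured. It differs from compound 1 in this way: amino in place of hydrogen on an aromatic carbon. Among the compounds with values here, no measured pair shows what such a change does here, so any expectation rests on compound 1 alone. The step from compound 1 to compound 4 in this assay is expected to be a number no higher from compound 1 to compound 4 (the limit leaves the size open), that is, none beyond the scatter. For compound 4 a value around 10000 nM is estimated, between 3000 nM and 30000 nM.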

Compound 4, concentration for 50% growth inhibition: > 10000 nM
Compound 4: no number, only a limit; the forecaster's own chance of this, stated with the estimate: 60%; the middle value sits exactly at the limit.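

Compound 1 and compound 4 both stop at a limit of the measurement, not a number, so no step between them can be read in this assay: the limit of > 10000 nM in this assay, at which 2 of the 4 values shown sit.

The compounds shown leave open what amino in place of hydrogen does to growth inhibition on this core.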